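A few compounds are considered here, and "the series" means these few. Any claim that something is new, unique, unknown or untested is made for them only; others in the source may bear on it.

In an ADME assay on the whole organism (plasma) for pharmacokinetics, with Rattus norvegicus as the target, with a stated time of 6 h, at a dose of 10 mg/kg by the oral route (a lower number here means less compound in the circulation, a higher number more compound in the circulation at the dose given), compound 1 `CNc1nc(C)c(-c2nc3ccccc3s2)c(N[C@@H]2C[C@H](CO)[C@@H](O)[C@H]2O)n1` gives 1080 ng.h/mL, the second highest of the three numbers: compound 2 `Cc1nc(NCC2CC2)nc(N[C@@H]2C[C@H](CO)[C@@H](O)[C@H]2O)c1-c1nc2ccccc2s1` gives 1410 ng.h/mL and compound 3 `Cc1nc(Nc2ccccc2)nc(N[C@@H]2C[C@H](CO)[C@@H](O)[C@H]2O)c1-c1nc2ccccc2s1` gives 742 ng.h/mL. Compound 4 `Cc1nc(NCc2cccs2)nc(N[C@@H]2C[C@H](CO)[C@@H](O)[C@H]2O)c1-c1nc2ccccc2s1` is not yet measured; it differs from compound 1 by thiophen-2-yl in place of hydrogen on a saturated chain carbon bound to a nitrogen on an aromatic ring. Within the data shown here, the closest precedent for a change at this place is a 1.3-fold higher number from compound 1 to compound 2 (0.12 log units; within the scatter). The larger changes on the nitrogen on the aromatic ring, a 1.5-fold lower number from compound 1 to compound 3 (0.16 log units; within the scatter) and a 1.9-fold lower number from compound 2 to compound 3 (0.28 log units; within the scatter), also stayed within the scatter. No step beyond the scatter is therefore expected in this assay from compound 1 to compound 4, the estimated step being a 1.1-fold lower number from compound 1 to compound 4 (0.06 log units; within the scatter). Compound 4 is expected to give about 950 ng.h/mL, with a range of 400 ng.h/mL to 2200 ng.h/mL.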

Compound 4, area under the concentration-time curve: 242 ng.h/mL
Estimate against measurement, compound 4: 3.9-fold (0.59 log units) above; the measured number lies below the stated range.
By their numbers in this assay, from the lowest: compound 4; then compounds 3, 1 and 2 (each within the scatter of the next).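

In this assay, among these compounds, the group on the saturated chain carbon bound to the nitrogen now counts: thiophen-2-yl gives a 4.5-fold lower number from compound 1 to compound 4 (0.65 log units; beyond the scatter) and, in place of cyclopropyl, a 5.8-fold lower number from compound 2 to compound 4 (0.77 log units; beyond the scatter) as the first steps beyond the scatter at this position. The step of a 3.1-fold lower number from compound 3 to compound 4 (0.49 log units; beyond the scatter) for (thiophen-2-yl)methyl in place of phenyl shows that an aromatic ring on this nitrogen does not by itself bring the number down this far. No data on hand bear on the origin of this drop.

Going by these compounds, whether the drop follows thiophene specifically or any ring on this chain carbon stays open: benzyl or furan-2-ylmethyl on the same nitrogen would separate the two. A longer chain such as butyl would show how a plain chain behaves here.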